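A few compounds are considered here, and "the series" means these few. Any claim that something is new, unique, unknown or untested is made for them only; others in the source may bear on it.

Three compounds built on the same shared core were tested in a functional assay on the whole organism (Tail, strain ICR) with Mus musculus as the target, in the tail flick test, with a stated time of 30 min, at a dose of 25 umol/kg by the oral route; on this read-out lower numbers stand for a weaker effect and higher numbers for a stronger effect at the one dose given. Compound 1 `N=C(N)NCCC[C@H](NC(=O)CN(c1nc(Cl)nc2[nH]cnc12)C1CC1)C(=O)O` gives 45.4%. Compound 2 `CC[C@H](C)[C@H](NC(=O)CN(c1nc(Cl)nc2[nH]cnc12)C1CC1)C(=O)O` gives 30.3%, and compound 3 `CSCC[C@H](NC(=O)CN(c1nc(Cl)nc2[nH]cnc12)C1CC1)C(=O)O` gives 20.4%. On these numbers compound 3 stands clearly apart from compound 1, the step being a number 25 percentage points lower from compound 1 to compound 3 (beyond the scatter), whereas the step of a number 9.9 percentage points lower from compound 2 to compound 3 (within the scatter) lies within the scatter, so compound 2 and compound 3 cannot be told apart. The step of a number 15.1 percentage points lower from compound 1 to compound 2 (beyond the scatter) likewise sets compound 1 apart from compound 2.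

Compound 4 `CC(C)C[C@H](NC(=O)CN(c1nc(Cl)nc2[nH]cnc12)C1CC1)C(=O)O` has not yet been measured. It differs from compound 3 in one place: isopropyl in place of (methylsulfanyl)methyl on a saturated chain carbon, two bonds along the chain from an amide-type nitrogen and a carbonyl carbon. The measured step that bears on this is a number 9.9 percentage points lower from compound 2 to compound 3 (within the scatter), where sec-butyl was exchanged for 2-(methylsulfanyl)ethyl with no change beyond the scatter; the two steps starting from compound 1 concern a different group and say nothing about this exchange. Because a number 9.9 percentage points lower from compound 2 to compound 3 (within the scatter) was within the scatter, the exchange of 2-(methylsulfanyl)ethyl for isobutyl is expected to give compound 4 a step of about a number 7.6 percentage points higher from compound 3 to compound 4 (within the scatter), which would place it close to compound 2. The estimate for compound 4 in this assay is 28%, with an expected range from 15% to 42%.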

Compound 4, a percentage reported as activity, at one dose (the size of the read-out at that dose, not a potency): 23.4%
Compound 4: middle estimate off by 4.6 percentage points, on the high side, within the range that was stated.
By their numbers in this assay, from the lowest: compounds 3, 4 and 2 (each within the scatter of the next); then compound 1.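

In this assay, the exchange of isopropyl for (methylsulfanyl)methyl, two bonds along the chain from an amide-type nitrogen and a carbonyl carbon, comes with a number 3 percentage points higher from compound 3 to compound 4 (within the scatter), so at this position an all-carbon group and a sulfur-containing group with the same heavy-atom count cannot be told apart. Isobutyl and sec-butyl cannot be told apart either, with a number 6.9 percentage points lower from compound 2 to compound 4 (within the scatter), while a number 22 percentage points lower from compound 1 to compound 4 (beyond the scatter) places compound 4 clearly apart from the nitrogen-bearing side chain of compound 1, so that compound 1 now stands apart from three side chains without nitrogen rather than two. Nothing measured here explains why these side chains group as they do.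

Among these compounds, compound 1 is the only compound here with nitrogen in its side chain, so it remains open whether a simple amine or a carboxylic acid at the end of a chain would fall near compound 1 or near the other three. A much shorter chain, such as methyl, or a longer all-carbon chain would show how far the all-carbon side chains stay alike.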